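Dropping a Methyl Group: From Compound 2 to Compound 4

The compounds below may be only part of what the source reports. "The series", "measured", "known", "first", "only" and "open" are said of these compounds alone.

The three measured compounds, each in a functional assay for inhibition, with Homo sapiens as the target; on this read-out lower numbers stand for stronger inhibition and higher numbers for weaker inhibition:
Compound 1 `CN(C)c1cccc(Nc2nccc(-c3cccnc3)n2)c1` gives 1800 nM.
Compound 2 `Cc1cccc(Nc2nccc(-c3ccc(C)o3)n2)c1` gives 2000 nM.
Compound 3 `COc1cccc(Nc2nccc(-c3ccc(C)o3)n2)c1` gives 1500 nM.

Compound 2 has the highest of the three numbers, but its nearest neighbour, compound 1, and its furthest, compound 3, both sit within the usual scatter of it, so nothing separates these three beyond measurement noise.

Compound 4 `Cc1cccc(Nc2nccc(-c3ccco3)n2)c1` has not been measured. It differs from compound 2 in one place: hydrogen in place of methyl on an aromatic carbon. Cut one bond further out, the change reads as 5-methylfuran-2-yl becoming furan-2-yl, with the hydrogen entering on an aromatic carbon of the five-membered aromatic ring, next to the ring oxygen.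

Within the data shown here, the only measured step between close neighbours is a 1.3-fold lower number from compound 2 to compound 3 (0.12 log units; within the scatter), and that concerns a methoxy in place of methyl on an aromatic carbon, not the loss of a methyl. Among the measured compounds shown here, no measured pair shows what removing this methyl does. With nothing pointing either way, the expected step is a 1.3-fold higher number from compound 2 to compound 4 (0.10 log units; within the scatter) in this assay, which amounts to no change beyond the scatter. Compound 4 is therefore estimated at 2500 nM, with a range from 1000 nM to 6500 nM.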

Compound 4, half-maximal inhibitory concentration: 2100 nM
Estimate against measurement, compound 4: 1.2-fold (0.08 log units) above; the measured number falls inside the stated range.
By their numbers in this assay, from the lowest: compounds 3, 1, 2 and 4 (each within the scatter of the next).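

Among these compounds, replacing 5-methylfuran-2-yl with furan-2-yl gives, in this assay, a 1.1-fold higher number from compound 2 to compound 4 (0.02 log units; within the scatter), the first measured pair that isolates this methyl, since the earlier step concerned methoxy in place of methyl at a different place. On an aromatic carbon of the five-membered aromatic ring, next to the ring oxygen, methyl and hydrogen therefore cannot be told apart on this read-out, so this pair gives no sign that the methyl matters to the measured number. No measured evidence bears on why the two compounds read alike.

As far as these compounds go, what this place does with a group other than methyl or hydrogen remains open: an ethyl chain, a chlorine atom, an amine or a carboxylic acid on the same carbon could give a very different number, and only such compounds would show whether the position responds to change at all. A single pair also leaves open whether hydrogen in place of this methyl would read the same way with the methoxy of compound 3 on the other side of the molecule.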